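From compound 3 to compound 4 at one dose

The source may hold more compounds than are shown below. What is called first, only, known or untested is meant among the compounds shown, and "the series" means these compounds.

Measured so far:
compound 1 `COc1cc(OC)c(OC)cc1/C=C/COC(=O)/C=C/c1ccc(OC)c(OC)c1` 100%
compound 2 `COc1cc(OC)c(OC)cc1/C=C/COC(=O)/C=C/c1ccccc1C(F)(F)F` 100%
compound 3 `COc1cc(OC)c(OC)cc1/C=C/COC(=O)/C=C/c1cccc(Br)c1` 100%

In a functional assay on the whole organism (strain Kunming) with Mus musculus as the target, with a stated time of 0.5 h, at a dose of 100 mg/kg by the intraperitoneal route (on this read-out lower numbers stand for a stronger effect and higher numbers for a weaker effect at the one dose given), compound 3 stands level with compounds 1 and 2 at the digits shown. The three measured steps, no change at the digits printed from compound 1 to compound 2 (within the scatter), no change at the digits printed from compound 1 to compound 3 (within the scatter) and no change at the digits printed from compound 2 to compound 3 (within the scatter), all swap the aryl group on a double-bonded chain carbon bound to a double-bonded chain carbon and all stay within the scatter.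

Compound 4 `COc1cc(OC)c(OC)cc1/C=C/COC(=O)/C=C/c1ccccc1Cl` is not yet measured. It differs from compound 3 as follows: 2-chlorophenyl in place of 3-bromophenyl on a double-bonded chain carbon bound to a double-bonded chain carbon. This change sits at the same place as the three measured swaps, each of which left the read-out unmoved, so no step beyond the scatter is expected, no change at the digits printed from compound 3 to compound 4 (within the scatter). Compound 4 is estimated to give 100%, within 90% to 100%.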

Compound 4, a percentage reported as activity, at one dose (the size of the read-out at that dose, not a potency): 100%
For compound 4 middle estimate and measured number coincide at the digits printed; the range from low to high includes it.
By their numbers in this assay, from the lowest: compounds 1, 2, 3 and 4 (each within the scatter of the next).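

In this assay, 2-chlorophenyl in place of 3-bromophenyl gives no change at the digits printed from compound 3 to compound 4 (within the scatter), and 2-chlorophenyl in place of 3,4-dimethoxyphenyl gives no change at the digits printed from compound 1 to compound 4 (within the scatter). Among the compounds shown here, the new compound also supplies the first step that exchanges only the group on an aromatic carbon, chloro in place of trifluoromethyl, with no change at the digits printed from compound 2 to compound 4 (within the scatter). Nothing available bears on why the read-out holds level across these changes.

Still open, as far as these compounds go, is whether an amine or a carboxylic acid on this aromatic ring would move the read-out. Also open, from the compounds shown here alone, is whether any change to the shared core would separate compounds that these aryl swaps do not.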